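This account rests on a few compounds, and the source may have more. Where it says the series, first, only, none or still open, it means among the compounds named here.

Measured so far:

Compound 1 `Nc1nc(NCc2cccc(F)c2)nc(-c2ccccc2CO)n1` gives 4.52 in a functional assay on cells for positive allosteric modulation of G-protein coupled receptor 68 (Homo sapiens), read by a luciferase reporter and cAMP accumulation, with a stated time of 30 min, at pH 6.8 and pH 8.3, in the presence of a further agent that is not named here; on this read-out lower numbers stand for lower potency and higher numbers for higher potency (the scale is a negative logarithm).
Compound 2 `Nc1nc(NCc2cccc(Cl)c2)nc(-c2ccccc2CO)n1` gives 4.97 in this assay.

Among the measured compounds shown here, compound 2 stands highest of these two numbers; its only neighbour is compound 1, and the single measured step between them, a number 0.45 log units higher from compound 1 to compound 2 (beyond the scatter), is a modest rise that lies beyond the usual scatter. That step exchanged one halogen for another at the same place on the ring.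

Compound 3 `Nc1nc(NCc2ccc(Cl)cc2)nc(-c2ccccc2CO)n1` has not been measured. It differs from compound 2 by 4-chlorophenyl in place of 3-chlorophenyl on a saturated chain carbon bound to a nitrogen on an aromatic ring; the chlorine is kept, only its place on the ring moves. No measured step addresses a shift of this kind, so the one step shown, from fluorine to chlorine, bears on it only indirectly: it says that chlorine at the original place is favourable, not what happens when chlorine moves. The most reasonable expectation for compound 3 is therefore a number close to that of compound 2, with a step of a number 0.07 log units lower from compound 2 to compound 3 (within the scatter) expected, which is within the scatter, and with a wide range on either side. Compound 3 is estimated at 4.9, between 4.4 and 5.4.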

Compound 3, negative logarithm of the antagonist equilibrium constant: 5.22
Beside the measured number, compound 3's estimate is 0.32 log units below it; the range from low to high includes it.
By their numbers in this assay, from the lowest: compound 1; then compounds 2 and 3 (each within the scatter of the next).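

Moving the chlorine from 3-chlorophenyl to 4-chlorophenyl, on the same saturated chain carbon bound to a nitrogen on an aromatic ring, gives a number 0.25 log units higher from compound 2 to compound 3 (within the scatter), so this assay does not separate these two placements, and the chlorine's place on the ring makes no clear difference here. The larger step, a number 0.70 log units higher from compound 1 to compound 3 (beyond the scatter), changes the halogen and its place together and cannot be divided between the two changes, but it does show that both chlorine compounds stand clearly apart from the fluorine compound, since the step to compound 2 also lies beyond the scatter. Nothing independent of these numbers is available to explain them.

The compounds shown leave open how a 4-fluorophenyl group would read, which would separate the effect of the halogen from that of its place, and how a plain phenyl group with no halogen would compare with all three. They also leave open whether a 4-methoxyphenyl group or a 4-aminophenyl group on the same carbon would hold the number seen with chlorine.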